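The source may hold more compounds than are shown below. What is called first, only, known or untested is meant among the compounds shown, and "the series" means these compounds.

Of the compounds shown here, three have so far been measured in a functional assay on HepG2 cells (Homo sapiens) for antiproliferative activity, read by MTT assay, with a stated time of 48 h; a higher number here means a weaker inhibitor, a lower number a stronger inhibitor. Compound 1 `Clc1ccccc1CSc1nnc(-c2cnccn2)o1` gives 12300 nM, compound 2 `Fc1ccc(CSc2nnc(-c3cnccn3)s2)cc1` gives 10100 nM, and compound 3 `Clc1ccccc1CSc1nnc(-c2cnccn2)n1-c1ccccc1` gives 18800 nM. Compound 3 therefore stands level with the other two, as its gaps to compound 1 and to compound 2 both lie within the usual scatter of repeated measurements. On these numbers, the three compounds cannot be separated in potency.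

The next compound, compound 4 `Clc1cccc(CSc2nnc(-c3cnccn3)n2-c2ccccc2)c1`, has the same atoms as compound 3, joined differently: 3-chlorophenyl in place of 2-chlorophenyl on a saturated chain carbon bound to a sulfur. It carries 3-chlorophenyl in place of 2-chlorophenyl on a saturated chain carbon bound to a sulfur. Among the compounds with values here, no measured pair of compounds isolates a change of this kind, so the data offer no direct precedent for it. The nearest guide is indirect: compound 2, at 10100 nM, differs from compound 3 in more than one place, yet remains within the scatter of it. No step beyond the scatter is therefore expected here, and neither direction is favoured. The estimated step of a 1.2-fold lower number from compound 3 to compound 4 (0.07 log units; within the scatter) is expected to stay within the scatter. In this assay the expected value for compound 4 is 16000 nM, with an estimated range from 7000 nM to 35000 nM.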

Compound 4, half-maximal inhibitory concentration: 19600 nM
Estimate against measurement, compound 4: 1.2-fold (0.09 log units) below; the range from low to high includes it.
By their numbers in this assay, from the lowest: compounds 2, 1, 3 and 4 (each within the scatter of the next).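

Within the data shown here, the set now holds its first pair differing in one place only, and so the first direct reading at the saturated chain carbon bound to a sulfur: 3-chlorophenyl in place of 2-chlorophenyl gives a step (a 1.0-fold higher number from compound 3 to compound 4 (0.02 log units; within the scatter)) that lies within the scatter in this assay. With the rest of the molecule held constant, these two placings of the chlorine on the phenyl ring cannot be told apart, a finding that extends to these two chlorophenyl groups and no further. Nothing at hand bears on why the two compounds read alike.

As far as these compounds go, it remains open whether this place responds to anything other than a chlorophenyl group, such as a phenyl ring carrying a methoxy group, an amine or a carboxylic acid in place of the chlorine, or a longer chain bound to the sulfur. Neither compound 1 nor compound 2 gives a single-place comparison with this pair, so the part played by the rest of the molecule also stays undecided.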